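Removing a Chloro Group on a Second Core

The compounds below may be only part of what the source reports. "The series", "measured", "known", "first", "only" and "open" are said of these compounds alone.

Of the compounds shown here, three have been measured in a functional assay on NIH3T3 cells (Mus musculus); a higher number here means that more compound is needed for the effect, a lower number that less compound is needed. Compound 1 `Cn1cncc1C(OCc1ccc(C#N)cc1-c1cccc(Cl)c1)c1ccc(C#N)nc1` gives 2.1 nM in this assay. Compound 3 `Cn1cncc1C(OCc1ccc(C#N)cc1-c1cc(Cl)cc(Cl)c1)c1ccc(C#N)nc1` gives 3.5 nM, and compound 2 `Cn1cncc1C(OCc1ccc(C#N)nc1-c1cc(Cl)cc(Cl)c1)c1ccc(C#N)cc1` gives 6 nM. Compound 2 and compound 3 are built from the same atoms joined differently; the difference between the two cores is not broken down here. Compound 1 and compound 3 differ in one place only: hydrogen in place of chloro on an aromatic carbon. That change gave a 1.7-fold lower number from compound 3 to compound 1 (0.22 log units; within the scatter).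

Compound 4 `Cn1cncc1C(OCc1ccc(C#N)nc1-c1cccc(Cl)c1)c1ccc(C#N)cc1` has not yet been measured in this assay. It differs from compound 2 in exactly the same way: hydrogen in place of chloro on an aromatic carbon. The place is described in the same words for both pairs, so this is the same change, now made on the core of compound 2 rather than on the core of compound 3.

Among the compounds with values here, only one measured example of this change exists, and it stayed inside the usual scatter, so there is no reason from the data to expect compound 4 to move far from compound 2. The expected step is a 1.7-fold lower number from compound 2 to compound 4 (0.23 log units; within the scatter), chosen because a 1.7-fold lower number from compound 3 to compound 1 (0.22 log units; within the scatter) was small. With a single example the uncertainty is wide. Compound 4 is therefore estimated to give about 3.5 nM in this assay, most likely somewhere between 1.5 nM and 9 nM.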

Compound 4, half-maximal effective concentration: 1.8 nM
Estimate against measurement, compound 4: 1.9-fold (0.29 log units) above; measured number inside the range.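

On the core of compound 2, going from 3,5-dichlorophenyl to 3-chlorophenyl gave a 3.3-fold lower number from compound 2 to compound 4 (0.52 log units; beyond the scatter) in this assay, so on this core the loss of one chloro group produces a step clear of the usual scatter. Set beside the same change on the other core, this step gives no firm sign that the two cores respond differently: the same change on two cores in this assay, a 1.7-fold lower number (0.22 log units; within the scatter) from compound 3 to compound 1 and a 3.3-fold lower number (0.52 log units; beyond the scatter) from compound 2 to compound 4, 2.0-fold (0.30 log units) apart, within the scatter of two such steps

This shows that, across these two pairs, the change can be carried from one core to the other without a difference in step size that stands out from the noise, but it does not show that the two steps are truly equal, and it cannot say how the change would behave on any third core, since the earlier step alone is too small to count as a clear change.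

The compounds shown compare only chloro with hydrogen at this one place on the phenyl ring, so it remains open what happens when the remaining chloro group is also replaced by hydrogen. From the compounds shown here alone, it also remains open whether a different group there, such as a methoxy group, a fluoro group or an amine, would give a number close to those seen here or a very different one.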